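The source may hold more compounds than are shown below. What is called first, only, known or untested is meant among the compounds shown, and "the series" means these compounds.

Measured in a functional assay on DLD-1 cells (Homo sapiens) for cytotoxicity, with a stated time of 48 h; a higher number here means a weaker inhibitor, a lower number a stronger inhibitor:
- compound 1 `CC(C)COc1ccc2oc(/C=C/[S+](C)[O-])cc(=O)c2c1`: 5000 nM
- compound 2 `C[S+]([O-])/C=C/c1cc(=O)c2cc(C#N)ccc2o1`: > 10000 nM (a limit)

Compound 2 gives > 10000 nM, which is a limit and not a number. That is the limit of > 10000 nM in this assay, at which 1 of the 2 values shown sits.

The next analogue is compound 3 `CC(C)C(=O)Oc1ccc2oc(/C=C/[S+](C)[O-])cc(=O)c2c1`, with (isopropylcarbonyl)oxy in place of cyano on an aromatic carbon.

Among the compounds with values here, only one measured step bears on this change: an at least 2.0-fold higher number from compound 1 to compound 2 (0.30 log units; that floor lies within the scatter). It also involves the cyano group, but there the cyano group enters, whereas here it leaves. Its size is only a floor, and that floor lies within the scatter, so it gives weak guidance. The one numerical anchor in this assay is compound 1 at 5000 nM. With the cyano group gone, a modest move toward lower numbers is expected, though a result at the limit remains quite possible.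

The expected change is an at least 1.6-fold lower number from compound 2 to compound 3 (0.22 log units; that floor lies within the scatter). For compound 3 the estimated value is 6000 nM, with an expected range of 2000 nM to 18000 nM.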

Compound 3, half-maximal inhibitory concentration: 9100 nM
Estimate against measurement, compound 3: 1.5-fold (0.18 log units) below, and the stated range covers the measured number.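

At this position, on an aromatic carbon para to a fused ring and meta to a fused ring, two groups attached through oxygen can now be compared by number in this assay: a 1.8-fold higher number from compound 1 to compound 3 (0.26 log units; within the scatter). Isopropylcarbonyl in place of isobutyl on that oxygen therefore gives no difference that can be told apart from the scatter, so this change does not separate the two groups. Against the cyano compound the reading is an at least 1.0-fold lower number from compound 2 to compound 3 (0.04 log units; that floor lies within the scatter), and this step fixes no size, because compound 2 holds a limit and not a number: the limit of > 10000 nM in this assay, at which 1 of the 3 values shown sits.

The compounds shown leave open whether the attachment through oxygen matters in itself, since a hydroxyl group, an amine or a longer chain on the oxygen at this position would be needed to separate the oxygen from what it carries. Within the data shown here, they also leave open whether any group here can move the number beyond the scatter from compound 1, which gives 5000 nM, as no measured step in this assay yet shows such a move.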